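Pyrimidine in Place of Pyrazole on the Amide Nitrogen

The compounds below may be only part of what the source reports. "The series", "measured", "known", "first", "only" and "open" are said of these compounds alone.

Compound 1 `Cc1ccc(OCC(=O)N(Cc2cccs2)c2ccnn2C)cc1` gives 422 nM in an assay on HEK293 cells for agonist activity at transient receptor potential cation channel subfamily M member 8 (Homo sapiens), read by fluorescence and calcium flux, with a stated time of 15 min (a higher number here means that more compound is needed for the effect, a lower number that less compound is needed), the highest of the two numbers recorded. Compound 2 `CCN(Cc1cccs1)C(=O)/C=C/c1ccc(C)cc1` gives 2 nM in this assay, a far lower number, beyond the scatter from compound 1. Compound 3 `Cc1ccc(OCC(=O)N(Cc2cccs2)c2ncccn2)cc1` is not yet measured and differs from compound 1 in one place: pyrimidin-2-yl in place of 1-methyl-1H-pyrazol-5-yl on an amide-type nitrogen. Within the data shown here, no measured pair shows this change, so only a small step, within or barely beyond the scatter and of uncertain direction, is expected: a 1.4-fold lower number from compound 1 to compound 3 (0.15 log units; within the scatter). For compound 3 the expected value in this assay is 300 nM, with a range from 60 nM to 1500 nM.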

Compound 3, half-maximal effective concentration: 3700 nM
Compound 3: middle estimate off by 12-fold (1.09 log units), on the low side; the measured number lies above the stated range.
By their numbers in this assay, from the lowest: compound 2; then compound 1; then compound 3.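

Putting pyrimidin-2-yl in place of 1-methyl-1H-pyrazol-5-yl on the amide-type nitrogen gives, in this assay, an 8.8-fold higher number from compound 1 to compound 3 (0.94 log units; beyond the scatter). This position therefore does not treat the two groups as interchangeable, although they match in heavy atoms, hetero atoms and hydrogen-bond acceptors as counted. They differ there as a five-membered and a six-membered aromatic ring, but no measured property accounts for the step. Going by these compounds, whether a phenyl or a pyridine ring on this nitrogen would fall nearer compound 1 or compound 3 remains open.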